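The source may hold more compounds than are shown below. What is called first, only, known or untested is meant among the compounds shown, and "the series" means these compounds.

Compound 1 `COc1cncc(-c2c(C)nn(-c3nc(-c4ccc(Cl)c(Cl)c4)c(SC(C)C)s3)c2C(=O)O)c1` carries a carboxy group and an isopropylthio substituent on its shared core, and in a functional assay on BJAB cells (Homo sapiens) for antiproliferative activity, with a stated time of 4 days (a lower number here means that less compound is needed, a higher number that more compound is needed for the effect), compound 1 gives 21000 nM. Going by the values given here, the only other measured member of the series, compound 2 `COC(=O)c1c(Cc2ccccc2[N+](=O)[O-])c(C)nn1-c1nc(-c2ccc(Cl)c(Cl)c2)cs1`, differs in several places at once and gives 377000 nM in this assay, so compound 1 holds the lower of the two numbers, and the gap between them lies well beyond the scatter of this assay. Compound 3 `Cc1cc(-c2c(C)nn(-c3nc(-c4ccc(Cl)c(Cl)c4)c(SC(C)C)s3)c2C(=O)O)cc(C)n1` has not yet been measured. It differs from compound 1 in a single place: 2,6-dimethylpyridin-4-yl in place of 5-methoxypyridin-3-yl on an aromatic carbon. Among the compounds with values here, the swap keeps the size of the group and the shared core otherwise unchanged, and no measured pair tests such a change. Compound 3 is therefore expected to give a number close to that of compound 1, with a step from compound 1 to compound 3 of a 1.3-fold lower number from compound 1 to compound 3 (0.12 log units; within the scatter), which is no larger than the scatter. The estimate for compound 3 in this assay is 16000 nM, within a range of 5000 nM to 50000 nM.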

Compound 3, half-maximal effective concentration: 580 nM
For compound 3 the middle estimate is 28-fold (1.44 log units) above the measured one, and the stated range ends above it.
By their numbers in this assay, from the lowest: compound 3; then compound 1; then compound 2.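

In this assay, replacing 5-methoxypyridin-3-yl with 2,6-dimethylpyridin-4-yl gives a 36-fold lower number from compound 1 to compound 3 (1.56 log units; beyond the scatter) on the aromatic carbon next to the ring atom that bears a carboxy group. This position therefore distinguishes sharply between two groups with the same count of heavy atoms, each built on one six-membered aromatic ring with 1 hetero atom. Nothing available explains the size of this step.

The single change alters the oxygen-bearing methoxy group, the two methyl groups and the attachment of the ring together, so the compounds shown leave open which of these matters. Going by these compounds, an unsubstituted pyridin-4-yl or a 2-methylpyridin-4-yl at this carbon would bear on that question, and how a primary amide in place of the carboxy group would behave alongside 2,6-dimethylpyridin-4-yl also remains open.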